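Changing the Sulfonyl Aryl Group of Compound 2

The compounds below may be only part of what the source reports. "The series", "measured", "known", "first", "only" and "open" are said of these compounds alone.

Among the compounds with values here, in a physicochemical assay for solubility, read by HPLC (a higher number here means a more soluble compound, a lower number a less soluble compound), compound 2 (`CN1Cc2cc(-c3ccc(-c4cncc(NS(=O)(=O)c5ccc(F)cc5F)c4)s3)cnc2C1=O`) gives 20300 ug/mL, the highest of the three numbers so far. Compound 1 (`O=C1NCc2ncc(-c3ccc(-c4cncc(NS(=O)(=O)c5ccc(F)cc5F)c4)s3)cc21`) gives 3770 ug/mL, and compound 3 (`O=C1NCc2cc(-c3ccc(-c4cncc(NS(=O)(=O)c5ccc(F)cc5F)c4)s3)cnc21`) gives 1130 ug/mL. The unmeasured compound 4 (`CN1Cc2cc(-c3ccc(-c4cncc(NS(=O)(=O)c5cccc(C(F)(F)F)c5)c4)s3)cnc2C1=O`) has 3-(trifluoromethyl)phenyl in place of 2,4-difluorophenyl on a sulfonyl sulfur. Within the data shown here, no measured step changes this group. The modest 5.4-fold higher number from compound 1 to compound 2 (0.73 log units; beyond the scatter) and the large 18-fold lower number from compound 2 to compound 3 (1.25 log units; beyond the scatter) involve other parts of the molecule, so they suggest only how far this assay can move in this small set, not the direction. A modest drop is therefore a tentative expectation. The estimated step is a 2.0-fold lower number from compound 2 to compound 4 (0.31 log units; beyond the scatter). For compound 4 the estimate is 10000 ug/mL, with an expected range of 2500 ug/mL to 30000 ug/mL.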

Compound 4, solubility: 20300 ug/mL
The estimate for compound 4 lay 2.0-fold (0.31 log units) below the measured number, within the range that was stated.
By their numbers in this assay, from the lowest: compound 3; then compound 1; then compounds 2 and 4 (each within the scatter of the next).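

In this assay, 3-(trifluoromethyl)phenyl in place of 2,4-difluorophenyl on a sulfonyl sulfur gives no change at the digits printed from compound 2 to compound 4 (within the scatter), the first step measured at this position. So here an entering group of 10 heavy atoms replaces one of 8 without a change beyond the scatter. Nothing available explains why the number held.

As far as these compounds go, this single pair swaps both fluorines and the trifluoromethyl group at once, so their separate contributions stay unknown. Also open, from the compounds shown here alone, is whether an aryl group carrying an amine or a carboxylic acid would move the number beyond the scatter.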